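Swapping one ring on a soluble compound

The source may report more compounds than this note shows. Statements on the series, on what has been measured and on what is new or still open speak of the compounds shown alone.

Compound 1 `Fc1ccc(-c2nc3cnc(Nc4ccccn4)cc3[nH]2)cc1F` gives >= 50000 nM as a limit of the assay, not a number
Compound 2 `FC(F)(F)c1ccc(Nc2cc3[nH]c(C4CCOCC4)nc3cn2)nc1` gives 168000 nM as a measured number

Among the compounds with values here, in a physicochemical assay for solubility, using the shake flask method, in simulated intestinal fluid, measured as kinetic solubility, with a stated time of 20 h, at pH 6.5 (a higher number here means a more soluble compound, a lower number a less soluble compound), compound 2 stands alone with 168000 nM as the only exact number so far. Compound 3 `FC1(F)CCC(c2nc3cnc(Nc4ccc(C(F)(F)F)cn4)cc3[nH]2)CC1` keeps the core of compound 2 and changes one group, with 4,4-difluorocyclohexyl in place of oxan-4-yl on an aromatic carbon as the whole difference. Within the data shown here, no measured step shows what this swap does, so any forecast is uncertain. A moderate fall in this assay beyond the usual scatter is expected. The estimated change is a 4.2-fold lower number from compound 2 to compound 3 (0.62 log units; beyond the scatter) in this forecast. Compound 3 is expected at 40000 nM with an estimated range from 10000 nM to 130000 nM for its measurement.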

Compound 3, solubility: 93000 nM
The estimate for compound 3 lay 2.3-fold (0.37 log units) below the measured number, within the range that was stated.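

At this position, on an aromatic carbon between two ring nitrogen atoms, putting 4,4-difluorocyclohexyl in place of oxan-4-yl gives a 1.8-fold lower number from compound 2 to compound 3 (0.26 log units; within the scatter) in this assay. The two compounds therefore cannot be told apart in this assay, even though the group that enters has no hydrogen-bond acceptor and the group that leaves has one. Compound 1 offers only a limit of the assay, not a number: the limit of >= 50000 nM in this assay, at which 1 of the 3 values shown sits.

Still open, as far as these compounds go, is whether an amine or a carboxylic acid at this position would shift the number beyond the scatter.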